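A few compounds are considered here, and "the series" means these few. Any claim that something is new, unique, unknown or untested is made for them only; others in the source may bear on it.

Measured compounds in a functional assay on HeLa cells (Homo sapiens) for antiproliferative activity, with a stated time of 24 h; a higher number here means a weaker inhibitor, a lower number a stronger inhibitor:
Compound 1, `NC(=O)c1c(NC(=O)c2ccccc2Cl)sc2c1CCN(Cc1ccccc1)C2`, gives 38400 nM.
Compound 2, `NC(=O)c1c(NC(=O)c2ccccc2Cl)sc2c1CCN(C(=S)Nc1ccccc1-c1ccccc1)C2`, gives 24000 nM.
Compound 3, `NC(=O)c1c(NC(=O)c2ccccc2Cl)sc2c1CCN(C(=S)Nc1ccc(C(F)(F)F)cc1)C2`, gives only a limit of the assay, > 50000 nM.

Compound 3 stands at the weak end of what has been measured so far: it reaches only the limit (the limit of > 50000 nM in this assay, at which 1 of the 3 values shown sits), so its true number is not known. Going by the values given here, the one step that touches its part of the molecule is an at least 2.0-fold higher number from compound 2 to compound 3 (0.31 log units; beyond the scatter), and it leads from a number into that limit. Compound 4, `COc1ccc(NC(=S)N2CCc3c(sc(NC(=O)c4ccccc4Cl)c3C(N)=O)C2)cc1`, changes compound 3 on the same ring: methoxy in place of trifluoromethyl on an aromatic carbon. Among the compounds with values here, no measured step compares a methoxy with a trifluoromethyl, so the measured steps give no direction for this change; the only guidance is that the earlier change on this ring, from compound 2 to compound 3, was at least modest. Compound 4 is therefore expected to sit near compound 3, with a wide range, at 40000 nM (from 15000 nM to 100000 nM), which as an expected step means an at least 1.2-fold lower number from compound 3 to compound 4 (0.09 log units; that floor lies within the scatter) and may again end as a limit.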

Compound 4, half-maximal inhibitory concentration: 36400 nM
Beside the measured number, compound 4's estimate is 1.1-fold (0.04 log units) above it; low and high end bracket the measured number.
By their numbers in this assay, from the lowest: compounds 2, 4 and 1 (each within the scatter of the next). At a limit, above all of these: compound 3.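

In this assay, methoxy in place of trifluoromethyl on this ring gives a measured number where there was only a limit, an outcome read as an at least 1.3-fold lower number from compound 3 to compound 4 (0.13 log units; that floor lies within the scatter). As far as these compounds go, the true size of that change stays unknown, and its floor alone cannot show a real gain, since compound 3 remains a limit: the limit of > 50000 nM in this assay, at which 1 of the 4 values shown sits. Compound 4 also shows no clear separation from the other two measured compounds, which differ in larger groups on the same ring nitrogen, with a 1.5-fold higher number from compound 2 to compound 4 (0.18 log units; within the scatter) and a 1.1-fold lower number from compound 1 to compound 4 (0.02 log units; within the scatter), so 4-methoxyphenyl matches 2-phenylphenyl and the group of compound 1 within the scatter.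

From the compounds shown here alone, it remains open whether an amine or a carboxylic acid at this ring carbon would shift the number beyond the scatter. Going by these compounds, how a smaller substituent such as fluorine would read there is equally open.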